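A Benzylsulfanyl Swap Against a Cytotoxicity Limit

The source may report more compounds than this note shows. Statements on the series, on what has been measured and on what is new or still open speak of the compounds shown alone.

In an ADME assay on MOLT-3 cells (Homo sapiens) for cytotoxicity, with a stated time of 7 days (on this read-out higher numbers stand for lower toxicity in this test and lower numbers for higher toxicity in this test), compound 3 `CCCCOc1nc(N)nc2c1ncn2/C=C1/CC1(CO)CO` gives > 20000 nM, which is a limit of the assay and not a number. Compound 1 `C=CCOc1nc(N)nc2c1ncn2/C=C1/CC1(CO)CO` gives > 20000 nM, and this too is a limit. Compound 2 `CC(C)CNc1nc(N)nc2c1ncn2/C=C1/CC1(CO)CO` offers no result, its entry reading "not determined" (no result reported). The measurements so far therefore amount to the limit of > 20000 nM in this assay, at which 2 of the 3 values shown sit, and compound 3 stands on that limit.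

Compound 4 `Nc1nc(SCc2ccccc2)c2ncn(/C=C3/CC3(CO)CO)c2n1` carries benzylsulfanyl in place of butoxy on an aromatic carbon, next to the ring nitrogen: benzylsulfanyl in place of butoxy on an aromatic carbon. Among the compounds with values here, only one measured step bears on this change, a step that the two limits leave unreadable from compound 1 to compound 3, which alters the chain in the group at this same place. Within the data shown here, it gives no usable size, and no measured compound carries benzylsulfanyl or any group with an aromatic ring there. The change in this assay therefore cannot be sized from the data, and the expectation starts from compound 3 at > 20000 nM. Compound 4 is expected to stay close to that limit, with a modest lean towards lower numbers allowed. The expected size of the change is a number no higher from compound 3 to compound 4 (the limit leaves the size open). For compound 4 the estimate is 20000 nM, with an expected range from 8000 nM to 50000 nM.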

Compound 4, half-maximal cytotoxic concentration: > 20000 nM
Compound 4 was reported as a limit (the forecaster's own chance of this, stated with the estimate: 65%); the middle value sits exactly at the limit.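

Compound 1, compound 3 and compound 4 all stand at a limit and not at a number, so the steps among them cannot be read and no size of change emerges in this assay: the limit of > 20000 nM in this assay, at which 3 of the 4 values shown sit.

The compounds shown leave open whether allyloxy, butoxy and benzylsulfanyl differ at all in this assay, and whether any group at this place would give a number.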